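The source may hold more compounds than are shown below. What is called first, only, known or untested is meant among the compounds shown, and "the series" means these compounds.

In a functional assay on the whole organism (Tail, strain ICR) with Mus musculus as the target, in the tail flick test, with a stated time of 150 min, at a dose of 25 umol/kg by the oral route (a lower number here means a weaker effect, a higher number a stronger effect of the compound at the dose given), three compounds of a shared core have been measured. Compound 1 `N=C(N)NCCC[C@H](NC(=O)CN(c1ncnc2c1ncn2C1CCCCO1)C1CC1)C(=O)OCc1ccccc1` gives 19.6%. Compound 2 `C[C@@H](O)[C@H](NC(=O)CN(c1nc(Cl)nc2[nH]cnc12)C1CC1)C(=O)O` gives 24%, the highest of the three numbers. Compound 3 `CC(C)[C@H](NC(=O)CN(c1nc(Cl)nc2[nH]cnc12)C1CC1)C(=O)OCc1ccccc1` gives 17.9%. The gap from compound 2 to compound 1 and the gap from compound 2 to compound 3 both lie within the usual scatter of this assay, so the three numbers cannot be set in an order of strength.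

Compound 4 `NC(=O)CC[C@H](NC(=O)CN(c1nc(Cl)nc2[nH]cnc12)C1CC1)C(=O)O` has not yet been measured in this assay. Against compound 2 it differs in one place: 2-carbamoylethyl in place of 1-hydroxyethyl on a saturated chain carbon bound to an amide-type nitrogen and a carbonyl carbon. The core, the cyclopropyl group on the amide-type nitrogen and the free carboxylic acid are kept.

Among the compounds with values here, no pair of measured compounds differing in a single place is available, so the size of the step cannot be read from the data. With the three measured numbers all close to one another, the step from compound 2 to compound 4 is expected to be small, a number 2 percentage points lower from compound 2 to compound 4 (within the scatter), in neither direction beyond the scatter. Compound 4 is therefore expected to give about 22% in this assay, estimated to fall between 12% and 32%.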

Compound 4, a percentage reported as activity, at one dose (the size of the read-out at that dose, not a potency): 11.4%
Compound 4: the middle estimate sits 10.6 percentage points above what was measured, outside the stated range (below it).
By their numbers in this assay, from the lowest: compounds 4, 3, 1 and 2 (each within the scatter of the next, the first and the last beyond it).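

Within the data shown here, this is the first step in this assay that can be read at a single position. On a saturated chain carbon bound to an amide-type nitrogen and a carbonyl carbon, 2-carbamoylethyl in place of 1-hydroxyethyl gives a number 12.6 percentage points lower from compound 2 to compound 4 (beyond the scatter), so with the core, the cyclopropyl group and the free carboxylic acid kept, this group alone moves the read-out beyond the scatter. No measurement at hand accounts for the step.

This one step does not separate the effect of the longer chain from that of its terminal carbamoyl group. On these data alone, what a carboxylic acid or an amine at the end of the chain, or a plain propyl chain, would give at this carbon remains open.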